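Propanoyl to acetyl on a plasma-stability series

A few compounds are considered here, and "the series" means these few. Any claim that something is new, unique, unknown or untested is made for them only; others in the source may bear on it.

Compound 1 `CCOC(=O)C1=C(S[C@@H]2CN[C@H](C(=O)Nc3cccc(C(=O)OCC)c3)C2)[C@H](C)[C@@H]2[C@@H]([C@@H](C)OC(=O)CC)C(=O)N12` gives 22% in an ADME assay on a cell-free system (plasma, Homo sapiens) for metabolic stability, read by LC-MS, with a stated time of 60 min, at 37 degrees C, tested at 50 uM; a lower number here means that less of the compound is left, a higher number that more of the compound is left.
Compound 2 `CCC(CC)C(=O)OCOC(=O)C1=C(S[C@@H]2CN[C@H](C(=O)Nc3cccc(C(=O)O)c3)C2)[C@H](C)[C@@H]2[C@@H]([C@@H](C)O)C(=O)N12` gives 82% in this assay.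
Compound 3 `C[C@@H](O)[C@H]1C(=O)N2C3=C(S[C@@H]4CN[C@@H](C4)C(=O)Nc4cccc(c4)C(=O)OCc4oc(=O)oc4COC3=O)[C@H](C)[C@H]12` gives 0% in this assay.

Of the three numbers, compound 1 stands second highest. Its nearest neighbour is compound 3, which lies lower by a margin beyond the usual scatter, while compound 2 lies far higher, again beyond the scatter. The difference between compound 1 and compound 2 is the widest of the set.

Compound 4 `CCOC(=O)C1=C(S[C@@H]2CN[C@H](C(=O)Nc3cccc(C(=O)OCC)c3)C2)[C@H](C)[C@@H]2[C@@H]([C@@H](C)OC(C)=O)C(=O)N12` has not yet been measured. It differs from compound 1 in one place: hydrogen in place of methyl on a saturated chain carbon bound to a carbonyl carbon. Put more fully, the propanoyloxy group of compound 1 becomes an acetoxy group in compound 4.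

For the measured compounds named here, since no step between measured compounds of this kind is available, the expectation for compound 4 rests on the small size of the change. Compound 4 is expected to remain close to compound 1, with a step of a number 4 percentage points lower from compound 1 to compound 4 (within the scatter) that is unlikely to reach beyond the scatter, perhaps slightly downward. The estimated value for compound 4 is 18%, within a range from 5% to 38%.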

Compound 4, percent of the compound remaining: 37%
Beside the measured number, compound 4's estimate is 19 percentage points below it; the range from low to high includes it.
By their numbers in this assay, from the lowest: compound 3; then compound 1; then compound 4; then compound 2.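

For the compounds shown here, replacing methyl with hydrogen on a saturated chain carbon bound to a carbonyl carbon, which turns propanoyloxy into acetoxy, gives the first one-place comparison of the series in this assay, with a number 15 percentage points higher from compound 1 to compound 4 (beyond the scatter). The step shows that this position is not silent: removing a single carbon from the chain changes how much compound is left, and the acetoxy group is the better of the two here. No measurement at hand explains the step.

One step cannot show whether the shift continues with a longer chain such as butanoyl or a branched group such as pivaloyl, or whether it reverses. As far as these compounds go, it also remains open whether the same change gives a similar step when a carboxylic acid replaces the ethyl ester on the benzene ring.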